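Swapping the amine substituent in a weaker sigma ligand

A few compounds are considered here, and "the series" means these few. Any claim that something is new, unique, unknown or untested is made for them only; others in the source may bear on it.

Compound 3 `COC1Cc2c(cnn2C)C2(CCN(Cc3ccc(F)cc3)CC2)O1` is the weakest of the three compounds measured in an assay for displacement of a labelled ligand from Sigma non-opioid intracellular receptor 1 (Cavia porcellus), read by scintillation counting, with a stated time of 180 min; on this read-out higher numbers stand for weaker inhibition and lower numbers for stronger inhibition: compound 3 gives 21 nM, whereas compound 2 `COC1Cc2c(cnn2-c2ccccc2)C2(CCN(CCCc3ccccc3)CC2)O1` gives 3.2 nM and compound 1 `COc1ccc(CN2CCC3(CC2)OC(OC)Cc2c3cnn2-c2ccccc2)cc1` gives 1.5 nM. Compound 3 differs from both of those in more than one place, so its gap to them cannot be assigned to a single change. The unmeasured compound 4 `COC1Cc2c(cnn2C)C2(CCN(CCCc3ccccc3)CC2)O1` is made from compound 3 by one change: phenethyl in place of 4-fluorophenyl on a saturated chain carbon bound to an amine nitrogen in a ring. For the measured compounds named here, one measured step bears on it, the same exchange on the same position of the shared core, a 2.1-fold higher number from compound 1 to compound 2 (0.33 log units; beyond the scatter), where a methoxy-bearing aryl rather than a fluorine-bearing aryl gives way to phenethyl, and on a core carrying phenyl instead of methyl on the pyrazole nitrogen. Taken at face value this points to a modest weakening, and compound 4 is therefore expected to sit slightly above compound 3, with a step of about a 1.7-fold higher number from compound 3 to compound 4 (0.22 log units; within the scatter). The estimate for compound 4 in this assay is 35 nM, with a likely range from 14 nM to 90 nM.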

Compound 4, inhibition constant: 93 nM
Compound 4: middle estimate off by 2.7-fold (0.42 log units), on the low side; the whole stated range lies below it.
By their numbers in this assay, from the lowest: compound 1; then compound 2; then compound 3; then compound 4.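

In this assay the exchange for phenethyl on a saturated chain carbon bound to an amine nitrogen in a ring again raises the number, a 4.4-fold higher number from compound 3 to compound 4 (0.65 log units; beyond the scatter) on the core with methyl on the aromatic nitrogen, so the direction of a 2.1-fold higher number from compound 1 to compound 2 (0.33 log units; beyond the scatter) also holds with 4-fluorophenyl leaving and on a second core. For the compounds shown here, the other new step, a 29-fold higher number from compound 2 to compound 4 (1.46 log units; beyond the scatter), gives the first single-change reading at the aromatic nitrogen, methyl in place of phenyl, and it is printed as large, whereas both exchanges on the amine side are modest. Nothing given here accounts for either step.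

The compounds shown leave open how an ethyl or a benzyl group on the aromatic nitrogen would read. They also leave open whether a cyclohexylmethyl group on the amine nitrogen would follow phenethyl on either core.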